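Extending an Ester Chain by One Carbon

This account rests on a few compounds, and the source may have more. Where it says the series, first, only, none or still open, it means among the compounds named here.

Measured so far:
compound 1, `CCCCCCCCCCOC(=O)CCC(=O)N1CCN(CCCOc2cc3c(Nc4ccc(F)c(Cl)c4)ncnc3cc2OC)CC1`: 2%
compound 2, `CCCCCCCCCCCCCOC(=O)CCC(=O)N1CCN(CCCOc2cc3c(Nc4ccc(F)c(Cl)c4)ncnc3cc2OC)CC1`: 6.8%

The two measured compounds share one core and differ only in the length of a saturated chain attached through an oxygen next to a carbonyl group. In a functional assay on A549 cells (Homo sapiens) for cytotoxicity, read by MTT assay, with a stated time of 24 h, tested at 80 uM (a higher number here means a weaker effect of the compound at the concentration tested, a lower number a stronger effect), compound 1 gives 2%, and compound 2 gives 6.8%. Within the data shown here, compound 2 holds the upper of the two numbers, but the only step that connects them, a number 4.8 percentage points higher from compound 1 to compound 2 (within the scatter), sits within the scatter, so the two readings cannot be told apart.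

Compound 3, `CCCCCCCCCCCCCCOC(=O)CCC(=O)N1CCN(CCCOc2cc3c(Nc4ccc(F)c(Cl)c4)ncnc3cc2OC)CC1`, has not yet been measured. It differs from compound 2 by methyl in place of hydrogen on a saturated chain carbon, ten or more bonds along the chain from an oxygen next to a carbonyl group. Among the measured compounds shown here, the one step that bears on this change is the one from compound 1 to compound 2, which put propyl in place of hydrogen at the same kind of position and came out within the scatter. A smaller change of the same kind is therefore expected to give no step beyond the scatter, a number 0.2 percentage points higher from compound 2 to compound 3 (within the scatter). Compound 3 is estimated to give 7%, with a range from 0% to 17%.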

Compound 3, a percentage reported as activity, at one concentration (the size of the read-out at that concentration, not a potency): 77.2%
Compound 3: middle estimate off by 70.2 percentage points, on the low side; measured number above the stated range.
By their numbers in this assay, from the lowest: compounds 1 and 2 (each within the scatter of the next); then compound 3.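

In this assay, methyl in place of hydrogen on a saturated chain carbon, ten or more bonds along the chain from an oxygen next to a carbonyl group, gives a number 70.4 percentage points higher from compound 2 to compound 3 (beyond the scatter), so even the smallest extension at this position can largely remove the effect seen at the tested concentration. Butyl in place of hydrogen at the same kind of position gives a number 75.2 percentage points higher from compound 1 to compound 3 (beyond the scatter), whereas the propyl change left compound 1 and compound 2 within the scatter of each other, so across these three compounds the response to chain length is an abrupt jump rather than a steady slope. Nothing available here explains why the reading jumps at this chain length.

The compounds shown leave open whether a still longer chain would keep the weak effect of compound 3 or bring back the stronger effect of compound 1 and compound 2. They also leave open whether the jump depends on the chain alone, which a version of compound 3 ending in an amine or a carboxylic acid could help to test.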